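The source may report more compounds than this note shows. Statements on the series, on what has been measured and on what is new or still open speak of the compounds shown alone.

Compound 1 `CCCCNC(=O)c1c(O)c2cccnc2n(-c2ccccc2)c1=O` carries a butyl group on an amide-type nitrogen, and in a functional assay on the whole organism for inhibition, with Rattus norvegicus as the target, read by cytopathic effect and paw edema, at a dose of 100 mg/kg by the oral route (a lower number here means less inhibition, a higher number more inhibition at the dose given (going by the name of the read-out)), compound 1 gives 20.4%. Among the three measured compounds this is the highest number. Compound 2 `Nc1ccc(NC(=O)c2c(O)c3cccnc3n(-c3ccccc3)c2=O)cc1`, with a 4-aminophenyl group in that place, gives 0% in this assay, and compound 3 `Cc1ccccc1NC(=O)c1c(O)c2cccnc2n(-c2ccccc2)c1=O`, with a 2-methylphenyl group there, gives 9.8%. Both aromatic replacements for butyl lowered the inhibition: a number 20.4 percentage points lower from compound 1 to compound 2 (beyond the scatter) and a number 10.6 percentage points lower from compound 1 to compound 3 (beyond the scatter). Between the two aromatic groups themselves the difference, a number 9.8 percentage points higher from compound 2 to compound 3 (within the scatter), stays within the scatter, so nothing separates them.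

Compound 4 `COc1ccc(NC(=O)c2c(O)c3cccnc3n(-c3ccccc3)c2=O)cn1` has not yet been measured. Its difference from compound 1 is 6-methoxypyridin-3-yl in place of butyl on an amide-type nitrogen. The two steps that bear on this change are the two exchanges of butyl for an aromatic group on the same nitrogen, and both went down by a modest amount beyond the scatter. Here again one six-membered aromatic ring enters in place of butyl, so a drop of similar size in this assay is expected rather than a gain. The inhibition of compound 4 is therefore estimated at 6%, with a range from 0% to 18%. This estimate means the expected step of a number 14.4 percentage points lower from compound 1 to compound 4 (beyond the scatter).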

Compound 4, a percentage reported as inhibition, in the whole organism at one dose (the size of the read-out at that dose, not a potency): -10.2%
Compound 4: middle estimate off by 16.2 percentage points, on the high side; the measured number lies below the stated range.
By their numbers in this assay, from the lowest: compound 4; then compounds 2 and 3 (each within the scatter of the next); then compound 1.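

In this assay the exchange on this amide-type nitrogen can go further than the two earlier aromatic groups showed: 6-methoxypyridin-3-yl in place of butyl gives the largest drop at this position, a number 30.6 percentage points lower from compound 1 to compound 4 (beyond the scatter), and compound 4 alone among the four reads negative at -10.2%. The aromatic groups are also not interchangeable, since the new group falls beyond the scatter from both of the others, with a number 20 percentage points lower from compound 3 to compound 4 (beyond the scatter) and a number 10.2 percentage points lower from compound 2 to compound 4 (beyond the scatter), although compound 2 and compound 3 remain within the scatter of each other, so the outcome depends on which ring enters and not only on the loss of butyl. No evidence is available on why this group gives the lowest number of the four.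

Since butyl is the only open chain here and compound 1 stands highest at 20.4%, the compounds shown leave open whether a longer chain, an isobutyl group or a cyclohexyl ring would hold or raise the inhibition. They also leave open whether the methoxy group or the ring nitrogen of the new group accounts for the step, which a plain phenyl or an unsubstituted pyridine ring would help to settle.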